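Replacing a Carboxy Side Chain with a Methylsulfanyl Group

The source may report more compounds than this note shows. Statements on the series, on what has been measured and on what is new or still open speak of the compounds shown alone.

Three close relatives share one core and differ only in the side chain of their amino-acid part. Compound 1 `NC(=O)C[C@H](NC(=O)CN(c1nc(Cl)nc2[nH]cnc12)C1CC1)C(=O)O` gives 20.1% in a functional assay on the whole organism (Tail, strain ICR) with Mus musculus as the target, in the tail flick test, with a stated time of 90 min, at a dose of 25 umol/kg by the oral route; a lower number here means a weaker effect, a higher number a stronger effect of the compound at the dose given; compound 2 `C[C@@H](O)[C@H](NC(=O)CN(c1nc(Cl)nc2[nH]cnc12)C1CC1)C(=O)O` gives 35.9%; compound 3 `O=C(O)C[C@H](NC(=O)CN(c1nc(Cl)nc2[nH]cnc12)C1CC1)C(=O)O` gives 25.1%, the second highest of the three, though its gap to compound 1 lies within the scatter. Compound 4 `CSCC[C@H](NC(=O)CN(c1nc(Cl)nc2[nH]cnc12)C1CC1)C(=O)O` carries (methylsulfanyl)methyl in place of carboxy on a saturated chain carbon, two bonds along the chain from an amide-type nitrogen and a carbonyl carbon. Every side-chain change seen so far was modest: a number 15.8 percentage points higher from compound 1 to compound 2 (beyond the scatter), a number 10.8 percentage points lower from compound 2 to compound 3 (beyond the scatter), and a number 5 percentage points higher from compound 1 to compound 3 (within the scatter). A swap at the same place is therefore expected to shift this assay only modestly, with no clear direction, so compound 4 is expected to move little, a step of a number 2.9 percentage points higher from compound 3 to compound 4 (within the scatter). Compound 4 is estimated at 28%, between 12% and 46%.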

Compound 4, a percentage reported as activity, at one dose (the size of the read-out at that dose, not a potency): 14%
Estimate against measurement, compound 4: 14 percentage points above, and the stated range covers the measured number.
By their numbers in this assay, from the lowest: compounds 4, 1 and 3 (each within the scatter of the next, the first and the last beyond it); then compound 2.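

In this assay, (methylsulfanyl)methyl in place of carboxy gives a number 11.1 percentage points lower from compound 3 to compound 4 (beyond the scatter) and so shows that this position does respond to losing carboxy, which the swap of carbamoyl for carboxy had not shown. The same group in place of carbamoyl gives a number 6.1 percentage points lower from compound 1 to compound 4 (within the scatter) while 2-(methylsulfanyl)ethyl in place of 1-hydroxyethyl gives a number 21.9 percentage points lower from compound 2 to compound 4 (beyond the scatter) and so the side chain of compound 2 remains the best of these four. Nothing measured here gives a reason for these steps.

Open, on these data alone, is whether a primary amine or a longer chain ending in hydroxy would keep or raise the effect at this place.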